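This account rests on a few compounds, and the source may have more. Where it says the series, first, only, none or still open, it means among the compounds named here.

Within the data shown here, in an assay on HeLa cells for inhibition of histone deacetylase 8 (Homo sapiens), read by fluorescence, with a stated time of 30 min (on this read-out lower numbers stand for stronger inhibition and higher numbers for weaker inhibition), compound 3 `O=C(CCCCCCOc1cccc(-c2nnc(-c3ccccc3)s2)c1)NO` gives 2390 nM, the lowest of the three numbers measured so far, although its companions sit close by: compound 2 `O=C(CCCCCOc1cccc(-c2nnc(-c3ccccc3)s2)c1)NO` gives 3030 nM and compound 1 `O=C(CCCCOc1cccc(-c2nnc(-c3ccccc3)s2)c1)NO` gives 3110 nM. The steps among these three, a 1.0-fold lower number from compound 1 to compound 2 (0.01 log units; within the scatter), a 1.3-fold lower number from compound 1 to compound 3 (0.11 log units; within the scatter) and a 1.3-fold lower number from compound 2 to compound 3 (0.10 log units; within the scatter), all fall within the usual scatter, so the three chain lengths cannot be told apart on these numbers and none of the three can be called the most potent.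

Compound 4 `O=C(CCCCCCOc1cccc(-c2nnc(-c3ccccc3Cl)s2)c1)NO` differs from compound 3 in one place: chloro in place of hydrogen on an aromatic carbon. Among the measured compounds shown here, no measured step touches this part of the molecule; all three concern only the length of the saturated chain, so nothing measured here speaks directly to a chloro on that ring. For the measured compounds named here, with only the steps of a 1.3-fold lower number from compound 1 to compound 3 (0.11 log units; within the scatter) and a 1.3-fold lower number from compound 2 to compound 3 (0.10 log units; within the scatter) as a guide to how gently this series has answered change so far, the step of a 1.2-fold lower number from compound 3 to compound 4 (0.08 log units; within the scatter) is expected to be small and to stay within the scatter, in either direction. Compound 4 is therefore estimated to give 2000 nM in this assay, with a range from 700 nM to 6000 nM to allow for the absence of any measured chloro substitution.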

Compound 4, half-maximal inhibitory concentration: 1520 nM
The estimate for compound 4 lay 1.3-fold (0.12 log units) above the measured number, and the stated range covers the measured number.
By their numbers in this assay, from the lowest: compounds 4, 3, 2 and 1 (each within the scatter of the next, the first and the last beyond it).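

Compound 4 is the first of these compounds changed on the phenyl ring rather than in the saturated chain, so it gives the first direct reading at this place, on an aromatic carbon ortho to a large group. In this assay, the change from phenyl to 2-chlorophenyl gives a 1.6-fold lower number from compound 3 to compound 4 (0.20 log units; within the scatter), so one added chlorine atom at this place leaves compound 4 and compound 3 indistinguishable, and this single step shows that the series keeps its inhibition with a chloro here, without showing any gain from it. No measurement is available here that would explain this result.

From the compounds shown here alone, it remains open whether a larger or differently built group at this place, such as methoxy, an amine or a carboxylic acid, would also leave the number within the scatter, or whether a chloro elsewhere on the same ring would do so. It is also open whether the chloro would give a similar step on the shorter chains of compound 1 and compound 2, since it is shown here only on the chain of compound 3.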